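A Methoxyphenyl Swap Tested Against Cell Toxicity

A few compounds are considered here, and "the series" means these few. Any claim that something is new, unique, unknown or untested is made for them only; others in the source may bear on it.

Measured compounds:
Compound 1 `CC1CCN(C2CCN(S(=O)(=O)c3ccc(F)cc3F)CC2)CC1`: > 5000 nM
Compound 2 `COc1ccccc1-c1ccc(S(=O)(=O)N2CCC(N3CCC(C)CC3)CC2)cc1`: > 5000 nM

In an ADME assay on HCT-116 cells (Homo sapiens) for cytotoxicity, read by CellTiter-Glo, with a stated time of 72 h (on this read-out higher numbers stand for weaker inhibition and lower numbers for stronger inhibition), compound 1 gives > 5000 nM, which is a limit of the assay rather than a number. Compound 2 in this assay gives > 5000 nM, also a limit. Among the measured compounds shown here, compound 1 therefore stands where every value so far stands: the limit of > 5000 nM in this assay, at which 2 of the 2 values shown sit.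

Compound 3 `COc1cccc(S(=O)(=O)N2CCC(N3CCC(C)CC3)CC2)c1` has not yet been measured. It differs from compound 1 in one place: 3-methoxyphenyl in place of 2,4-difluorophenyl on a sulfonyl sulfur. For the measured compounds named here, no step between two measured compounds is available, so no direction of change can be read from the data; the expectation is for no step beyond the scatter in this assay, with the result likely remaining a limit. Compound 3 is expected to give about 8000 nM, within 3000 nM to 30000 nM, in this assay, because compound 1 sits at > 5000 nM. This corresponds to an expected step that the limit leaves unreadable from compound 1 to compound 3.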

Compound 3, half-maximal inhibitory concentration: > 5000 nM
Compound 3 ended at the assay's limit; the forecaster's own chance of this, stated with the estimate: 75%; the middle value does not contradict the limit.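

Among the compounds shown here, compound 1 and compound 3 both stand at a limit rather than at a number in this assay, so no step between them can be read, neither its size nor its direction. Still open is how strongly any compound shown inhibits these cells: the limit of > 5000 nM in this assay, at which 3 of the 3 values shown sit.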